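A few compounds are considered here, and "the series" means these few. Any claim that something is new, unique, unknown or untested is made for them only; others in the source may bear on it.

Measured compounds:
- Compound 1, `Cc1c(COc2cccc(OCC3CCOCC3)c2)[nH]c2ccc(-c3cccnc3)cc2c1=O`: 756 mL/min/kg
- Compound 2, `Cc1c(COCCCCOCC2(C)COC2)[nH]c2ccccc2c1=O`: 53 mL/min/kg

In an in vitro ADME assay on microsomes from liver (Homo sapiens) for metabolic stability, tested at 0.2 uM (a higher number here means faster removal of the compound, a lower number slower removal), compound 1 gives 756 mL/min/kg, the higher of the two numbers, and compound 2 gives 53 mL/min/kg; the gap between them lies beyond the scatter. Compound 1 is thus removed far faster in this assay than compound 2, though the two share only the core and differ at several points, so the comparison fixes no single cause.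

Compound 3, `Cc1c(COc2cccc(OCC3CCOCC3)c2)[nH]c2ccccc2c1=O`, is not yet measured. It differs from compound 1 in one place: hydrogen in place of pyridin-3-yl on an aromatic carbon. The aryl ether chain and its tetrahydropyranylmethoxy group are kept.

Among the compounds with values here, no measured pair isolates this change, so its direction rests on expectation alone. The step from compound 1 to compound 3 is expected to be a 2.2-fold lower number from compound 1 to compound 3 (0.33 log units; beyond the scatter), a modest fall that may not clear the scatter. For compound 3 the estimated clearance is 350 mL/min/kg, within a range of 120 mL/min/kg to 900 mL/min/kg.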

Compound 3, clearance: 214 mL/min/kg
Compound 3: the middle estimate sits 1.6-fold (0.21 log units) above what was measured, and the stated range covers the measured number.
By their numbers in this assay, from the lowest: compound 2; then compound 3; then compound 1.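

Within the data shown here, replacing the pyridin-3-yl group on the aromatic carbon with hydrogen, with the aryl ether chain and its tetrahydropyranylmethoxy group kept, gives a 3.5-fold lower number from compound 1 to compound 3 (0.55 log units; beyond the scatter) in this assay and is the first single-place comparison here, showing that this position affects the number. The change does not remove the clearance, however, since compound 3 still gives 214 mL/min/kg in this assay without the pyridin-3-yl group. Nothing available explains the step.

The compounds shown leave open whether the step is tied to the pyridin-3-yl ring itself or would also follow from a phenyl ring, a fluorine or a morpholine at this place. They also leave open how the number responds in the chain, for example if an amine or a shorter chain replaces the tetrahydropyranylmethoxy group.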